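Chloro to hydrogen on a shared core: expecting compound 4

A few compounds are considered here, and "the series" means these few. Any claim that something is new, unique, unknown or untested is made for them only; others in the source may bear on it.

The measured compounds, all read in a functional assay on MCF7 cells (Homo sapiens) for cytotoxicity, read by XTT assay, with a stated time of 24 h; on this read-out higher numbers stand for weaker inhibition and lower numbers for stronger inhibition:
compound 1 `Cc1cc(Cl)c2c(c1O)C(=O)C=CC2=O` gives 10000 nM;
compound 2 `CCOc1cc(C)cc2c1C(=O)C=CC2=O` gives 23700 nM;
compound 3 `CCOc1cc(C)c(Cl)c2c1C(=O)C=CC2=O` gives 40000 nM.

Compound 1 has the lowest number of the three, and its gaps to compound 2 and to compound 3 both lie beyond the usual scatter of this assay. Between compound 3 and compound 2 a single change was made, (hydrogen in place of chloro on an aromatic carbon), and it gave a 1.7-fold lower number from compound 3 to compound 2 (0.23 log units; within the scatter). How the core of compound 1 differs from the core of compound 3 is not broken down here.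

Compound 4 `Cc1ccc2c(c1O)C(=O)C=CC2=O` is the not yet measured partner of compound 1. It differs from compound 1 by hydrogen in place of chloro on an aromatic carbon. This is the same kind of change as that from compound 3 to compound 2, but the surroundings differ: there the position was ortho to a methyl group and para to an ethoxy group, here it is meta to a methyl group and para to a hydroxy group.

Because the earlier step, a 1.7-fold lower number from compound 3 to compound 2 (0.23 log units; within the scatter), stayed within the scatter, the step from compound 1 to compound 4 is expected to be small, a 1.4-fold lower number from compound 1 to compound 4 (0.15 log units; within the scatter). Compound 4 is therefore estimated at 7000 nM in this assay, with an expected range from 2500 nM to 20000 nM.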

Compound 4, half-maximal inhibitory concentration: 15300 nM
Compound 4: the middle estimate sits 2.2-fold (0.34 log units) below what was measured; low and high end bracket the measured number.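

In this assay, hydrogen in place of chloro on the core of compound 1 gave a 1.5-fold higher number from compound 1 to compound 4 (0.18 log units; within the scatter). Set beside the earlier step, neither step leaves the scatter, and neither does the gap between them: the same change on two cores in this assay, a 1.7-fold lower number (0.23 log units; within the scatter) from compound 3 to compound 2 and a 1.5-fold higher number (0.18 log units; within the scatter) from compound 1 to compound 4, 2.6-fold (0.41 log units) apart, within the scatter of two such steps. On these two cores, then, the change carries over as a small step with no measurable dependence on the core, but two pairs cannot show whether its direction really differs between the cores, and they say nothing about any core beyond these two.

The compounds shown leave open how a group other than chloro or hydrogen, such as a bromine atom, a methoxy group or an amine, would read on this aromatic carbon. They also leave open what a longer chain in place of the ethoxy group, or a carboxylic acid elsewhere on the shared core, would do to the number in this assay.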